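Benzylselanyl in Place of Methylsulfanyl on Two Cores

The source may hold more compounds than are shown below. What is called first, only, known or untested is meant among the compounds shown, and "the series" means these compounds.

Compound 1, `CS/C(=N\C(=O)c1ccno1)NC(=O)c1ccno1`, gives > 100000 nM in a functional assay on PC-3 cells (Homo sapiens) for cytotoxicity, read by MTT assay, with a stated time of 72 h (a higher number here means that more compound is tolerated, a lower number that less compound is tolerated), a limit of the assay.
Compound 2, `CS/C(=N\C(=O)c1cc2ccccc2s1)NC(=O)c1cc2ccccc2s1`, gives 72600 nM in this assay.
Compound 3, `O=C(/N=C(/NC(=O)c1ccno1)[Se]Cc1ccccc1)c1ccno1`, gives > 100000 nM in this assay, a limit of the assay.

Only compound 2 yields an actual number; compound 1 and compound 3 each reach only a limit. The change from compound 1 to compound 3 is a group of 8 heavy atoms (7 carbon, 1 selenium; one six-membered aromatic ring of carbon only) in place of a group of 2 heavy atoms (1 carbon, 1 sulfur; no ring), on a carbon with a double bond to nitrogen. The step it made, a step that the two limits leave unreadable from compound 1 to compound 3, cannot be read because of the limit of > 100000 nM in this assay, at which 2 of the 3 values shown sit. The cores of compound 1 and compound 2 differ, but that difference is not broken down here.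

Compound 4, `O=C(/N=C(/NC(=O)c1cc2ccccc2s1)[Se]Cc1ccccc1)c1cc2ccccc2s1`, has not yet been measured. It carries the same change on the core of compound 2, namely (a group of 8 heavy atoms (7 carbon, 1 selenium; one six-membered aromatic ring of carbon only) in place of a group of 2 heavy atoms (1 carbon, 1 sulfur; no ring), on a carbon with a double bond to nitrogen), at the same place as before. For the measured compounds named here, because compound 2 gives 72600 nM and the only measured instance of this change, a step that the two limits leave unreadable from compound 1 to compound 3, is unreadable, the step expected for compound 4 is about a 1.1-fold lower number from compound 2 to compound 4 (0.05 log units; within the scatter). Compound 4 is therefore estimated at 65000 nM, with a plausible range from 20000 nM to 100000 nM, and a fair chance that only a limit is reported.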

Compound 4, concentration lethal to 50% of the cells: 86300 nM
The estimate for compound 4 lay 1.3-fold (0.12 log units) below the measured number, within the range that was stated.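

In this assay, the benzylselanyl group in place of methylsulfanyl gives a 1.2-fold higher number from compound 2 to compound 4 (0.08 log units; within the scatter), so on this core the swap leaves the read-out indistinguishable from that of the parent compound. The same swap on the other core gives no readable step, because both of its compounds sit at a limit of the assay and not at a number: the limit of > 100000 nM in this assay, at which 2 of the 4 values shown sit. The series therefore holds a single readable instance of this change, which shows that the swap can be made on one core without a step beyond the scatter, but does not show that the two cores respond alike or that the result would carry over to any further core.

The swap changes the sulfur to selenium and the methyl to a group holding an aromatic ring in one move, so the compounds shown leave open what each part contributes on its own. A benzylsulfanyl or a methylselanyl group on the same carbon would separate the two, and an amine there would test a group of a different kind.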